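Swapping a fluoro for a trifluoromethyl on the pendant ring

The compounds below may be only part of what the source reports. "The series", "measured", "known", "first", "only" and "open" are said of these compounds alone.

Compound 1 `Cc1cc(-c2cccc(C(F)(F)F)c2)cc(C)c1Nc1ccnc(Nc2ccc(C#N)cc2)n1` gives 4030 nM in an ADME assay on MT4 cells (Homo sapiens) for cytotoxicity, read by MTT assay, with a stated time of 4 days; a higher number here means that more compound is tolerated, a lower number that less compound is tolerated.
Compound 2 `Cc1cc(-c2cccc(F)c2)cc(C)c1Nc1ccnc(Nc2ccc(C#N)cc2)n1` gives 4120 nM in this assay.

Compound 2 holds the higher of the two numbers, but its nearest neighbour compound 1 lies within the scatter of it. Compound 3 `Cc1cc(-c2ccc(C(F)(F)F)cc2)cc(C)c1Nc1ccnc(Nc2ccc(C#N)cc2)n1` carries 4-(trifluoromethyl)phenyl in place of 3-fluorophenyl on an aromatic carbon. Among the compounds with values here, the only measured step that bears on this, a 1.0-fold higher number from compound 1 to compound 2 (0.01 log units; within the scatter), shows that exchanging a fluoro for a trifluoromethyl on this ring left the reading unchanged. Compound 3 is therefore expected to show a 1.0-fold lower number from compound 2 to compound 3 (0.00 log units; within the scatter), no shift beyond the scatter. The estimate for compound 3 in this assay is 4100 nM, between 2000 nM and 8500 nM.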

Compound 3, half-maximal cytotoxic concentration: 4160 nM
Beside the measured number, compound 3's estimate is 1.0-fold (0.01 log units) below it; the range from low to high includes it.
By their numbers in this assay, from the lowest: compounds 1, 2 and 3 (each within the scatter of the next).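

In this assay, the trifluoromethyl group can take either of the two ring positions shown: the step is a 1.0-fold higher number from compound 1 to compound 3 (0.01 log units; within the scatter). The exchange of 3-fluorophenyl for 4-(trifluoromethyl)phenyl, which alters both the group and its position at once, gives a 1.0-fold higher number from compound 2 to compound 3 (0.00 log units; within the scatter). Nothing available explains why these readings lie so close together. The aromatic substituents shown here are only fluoro and trifluoromethyl, so the compounds leave open whether an amine or a carboxylic acid on this ring would also stay within the scatter.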